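This account rests on a few compounds, and the source may have more. Where it says the series, first, only, none or still open, it means among the compounds named here.

Measured compounds in a functional assay on K562 cells (Homo sapiens) for antiproliferative activity, with a stated time of 72 h; a higher number here means a weaker inhibitor, a lower number a stronger inhibitor:
compound 1 `OC[C@H]1O[C@@H](n2cnc3c(NCc4ccc(Br)cc4)ncnc32)[C@H](O)[C@@H]1O` gives 68200 nM
compound 2 `Cc1ccc(CNc2ncnc3c2ncn3[C@@H]2O[C@H](CO)[C@@H](O)[C@H]2O)cc1` gives > 166000 nM, which is a limit of this assay and not a number.

On the numbers shown, compound 2 stands only at a limit in this assay, as the limit of > 166000 nM in this assay, at which 1 of the 2 values shown sits, records. Compound 3 `COc1cc(CNc2ncnc3c2ncn3[C@@H]2O[C@H](CO)[C@@H](O)[C@H]2O)cc(OC)c1` carries 3,5-dimethoxyphenyl in place of 4-methylphenyl on a saturated chain carbon bound to a nitrogen on an aromatic ring. Among the compounds with values here, the one measured step in this assay, an at least 2.4-fold higher number from compound 1 to compound 2 (0.38 log units; beyond the scatter), concerns the same aryl part and is itself bounded by a limit, so it gives no read on whether 3,5-dimethoxyphenyl moves the number back below that limit. A step that the limit leaves unreadable from compound 2 to compound 3 is expected, with a fair chance this assay again reports only a limit. For compound 3 the estimate in this assay is 200000 nM, within 60000 nM to 600000 nM.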

Compound 3, half-maximal inhibitory concentration: > 166000 nM
Compound 3: only a limit was reported; the forecaster's own chance of this, stated with the estimate: 70%; the middle value lies beyond the limit too.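

In this assay compound 3 gives > 166000 nM, which is a limit and not a number. With 3,5-dimethoxyphenyl in place of 4-bromophenyl, the series shows an at least 2.4-fold higher number from compound 1 to compound 3 (0.38 log units; beyond the scatter), so a second aryl group at this place also fails to reach the value of compound 1. The step between compound 2 and compound 3 cannot be read, as both sit at the same limit: the limit of > 166000 nM in this assay, at which 2 of the 3 values shown sit.

Going by these compounds, it remains open whether the bromo group itself sets the measurable value of compound 1. A 4-chlorophenyl or 4-iodophenyl group at this place would bear on that.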